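The compounds below may be only part of what the source reports. "The series", "measured", "known", "first", "only" and "open" are said of these compounds alone.

Compound 1, `CCOC(=O)c1cnn(-c2nc(-c3ccc(OC)cc3)c(C#N)c(=O)n2C)c1N`: 59 ug/mL
Compound 2, `CCOC(=O)c1cnn(-c2nc(-c3ccco3)c(C#N)c(=O)n2C)c1N`: 91 ug/mL

Both compounds share one core and differ only in the aromatic group attached to it. In a functional assay, with a stated time of 20 min (a higher number here means a weaker inhibitor, a lower number a stronger inhibitor), compound 1 gives 59 ug/mL, and compound 2 gives 91 ug/mL. Going by the values given here, the single step that connects them, a 1.5-fold higher number from compound 1 to compound 2 (0.19 log units; within the scatter), is too small to tell the two apart, so compound 2 stands level with compound 1 on these numbers.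

Compound 3, `CCOC(=O)c1cnn(-c2nc(-c3cccc(O)c3O)c(C#N)c(=O)n2C)c1N`, is one step away from compound 2: 2,3-dihydroxyphenyl in place of furan-2-yl on an aromatic carbon. Among the compounds with values here, the only measured step that bears on this change is the one at the same position, a 1.5-fold higher number from compound 1 to compound 2 (0.19 log units; within the scatter), where one aromatic group replaced another and the number hardly moved. Within the data shown here, with only that one step to go on, no movement beyond the scatter is expected in this assay for compound 3, in either direction. The estimate for compound 3 is therefore 65 ug/mL, expected to fall between 25 ug/mL and 170 ug/mL. The step this implies is expected to be a 1.4-fold lower number from compound 2 to compound 3 (0.15 log units; within the scatter).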

Compound 3, half-maximal inhibitory concentration: 41 ug/mL
The estimate for compound 3 lay 1.6-fold (0.20 log units) above the measured number, within the range that was stated.
By their numbers in this assay, from the lowest: compounds 3, 1 and 2 (each within the scatter of the next, the first and the last beyond it).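

Going by these compounds alone, at this position, on the aromatic carbon ortho to a cyano group, the earlier pair gave no step beyond the scatter in this assay, whereas 2,3-dihydroxyphenyl in place of furan-2-yl gives a 2.2-fold lower number from compound 2 to compound 3 (0.35 log units; beyond the scatter), the first step here that can be told apart from the scatter, though only a modest one. The same group in place of 4-methoxyphenyl gives a 1.4-fold lower number from compound 1 to compound 3 (0.16 log units; within the scatter), so the difference holds against furan-2-yl only, and compound 3 stands level with compound 1 on these numbers. No independent measurement is available to explain the step from furan-2-yl.

All three groups at this position are aromatic rings, so the compounds shown leave open whether a non-aromatic group there, such as an amine or a short alkyl chain, would fall in the same range. They also leave open whether both hydroxyl groups of 2,3-dihydroxyphenyl are needed for the step from compound 2, a question that 2-hydroxyphenyl and 3-hydroxyphenyl, each carrying a single hydroxyl, could address.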